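The source may report more compounds than this note shows. Statements on the series, on what has been measured and on what is new or still open speak of the compounds shown alone.

Of the compounds shown here, two have been tested in an assay on membranes from brain for binding affinity to Lysophosphatidylserine lipase ABHD12 (Mus musculus), read by fluorescence, with a stated time of 20 min; a lower number here means a stronger inhibitor, a higher number a weaker inhibitor. Compound 1 `FC(F)(F)Oc1ccccc1Oc1ccnc(N2CCC(NC(=S)Nc3cccnc3)CC2)c1Cl` gives 96 nM. Compound 2 `S=C(Nc1cccnc1)NC1CCN(c2cc(OCc3ccccc3)ccn2)CC1` gives 2800 nM, the higher of the two numbers, so of these two it is the weaker inhibitor, and the gap to compound 1 lies well beyond the scatter of the method.

Compound 3 `COc1ccnc(N2CCC(NC(=S)Nc3cccnc3)CC2)c1` differs from compound 2 in one place: hydrogen in place of phenyl on a saturated chain carbon bound to an oxygen on an aromatic ring. Put more simply, the benzyloxy group on the core of compound 2 becomes a methoxy group, and the whole phenyl ring is gone.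

Going by the values given here, no step of this kind has been measured here, so its effect is unknown. Taking away a full aromatic ring from a compound that already stands at 2800 nM is expected to push the number upward rather than down, by a step estimated as a 3.6-fold higher number from compound 2 to compound 3 (0.55 log units; beyond the scatter). Compound 3 is therefore expected to give about 10000 nM in this assay, with a likely range from 3000 nM to 40000 nM.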

Compound 3, half-maximal inhibitory concentration: > 5000 nM
Compound 3 ended at the assay's limit; the forecaster's own chance of this, stated with the estimate: 30%; the middle value does not contradict the limit.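

In this assay compound 3 gives > 5000 nM, which is a limit of the assay and not a number. Cutting the benzyloxy group back to methoxy is read as an at least 1.7-fold higher number from compound 2 to compound 3 (0.25 log units; that floor lies within the scatter), so removing the phenyl gives no sign of a stronger inhibitor, though this floor alone does not prove a real loss. How large the step truly is cannot be read because compound 3 stops at the limit: the limit of > 5000 nM in this assay, at which 1 of the 3 values shown sits.

On these data alone, it remains open how a longer chain at this oxygen, such as phenethyloxy, or a benzylamine in place of benzyloxy would read in this assay. Compound 1 differs from compound 2 and compound 3 in more than one place, so its lower number cannot be tied to this position.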